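Trimethoxyphenyl pyrazole enones: aminophenyl to difluorophenyl on the carbonyl

A few compounds are considered here, and "the series" means these few. Any claim that something is new, unique, unknown or untested is made for them only; others in the source may bear on it.

Measured compounds:
compound 1 `COc1cc(-c2cc(/C=C/C(=O)c3ccc(N)cc3)[nH]n2)cc(OC)c1OC` – -9%
compound 2 `COc1ccc(-c2cc(/C=C/C(=O)c3ccc(N)cc3)[nH]n2)cc1OC` – 29%
compound 3 `COc1ccc(-c2cc(/C=C/C(=O)c3cc(OC)c(OC)c(OC)c3)[nH]n2)cc1OC` – 37%

For the measured compounds named here, in a functional assay on SK-OV-3 cells (Homo sapiens) for cytotoxicity, read by sulforhodamine B assay, with a stated time of 48 h, tested at 10 uM (on this read-out higher numbers stand for a weaker effect at the one concentration tested and lower numbers for a stronger effect), compound 1 gives the lowest number of the three, with a number 38 percentage points higher from compound 1 to compound 2 (beyond the scatter) the only step measured so far, and that step concerns a different ring of the shared core. Compound 4 `COc1cc(-c2cc(/C=C/C(=O)c3ccc(F)c(F)c3)[nH]n2)cc(OC)c1OC` differs from compound 1 by 3,4-difluorophenyl in place of 4-aminophenyl on a carbonyl carbon. Going by the values given here, no measured step bears directly on this change; the closest comparison is compound 2 against compound 3, where a different ring on the carbonyl carbon leaves the two values within the scatter of each other. A modest step in this assay is therefore expected, most likely a somewhat higher number, with wide uncertainty. For compound 4 the estimate is 8% (range -15% to 35%), corresponding to an expected a number 17 percentage points higher from compound 1 to compound 4 (beyond the scatter).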

Compound 4, a percentage reported as activity, at one concentration (the size of the read-out at that concentration, not a potency): 17%
Beside the measured number, compound 4's estimate is 9 percentage points below it; the range from low to high includes it.
By their numbers in this assay, from the lowest: compound 1; then compound 4; then compounds 2 and 3 (each within the scatter of the next).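

In this assay, the carbonyl carbon proves sensitive to the group it carries: with the rest of the core of compound 1 unchanged, 3,4-difluorophenyl in place of 4-aminophenyl gives a number 26 percentage points higher from compound 1 to compound 4 (beyond the scatter). For the compounds shown here, the earlier single-place step concerned a different ring, so this is the first direct reading at this position. Nothing measured accounts for the shift. From the compounds shown here alone, whether loss of the amine or arrival of the two fluorines drives the step stays open. A plain phenyl or 4-fluorophenyl on the carbonyl carbon would separate these two contributions.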